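This account rests on a few compounds, and the source may have more. Where it says the series, first, only, none or still open, it means among the compounds named here.

In a functional assay on SiHa cells (Homo sapiens) for antiproliferative activity, read by CCK-8 assay, with a stated time of 72 h (a lower number here means a stronger inhibitor, a higher number a weaker inhibitor), compound 1 `COc1cc(-c2ncncc2-c2ccc(SC)cc2)cc(OC)c1OC` gives 560 nM and compound 2 `CCOc1ccc(-c2cncnc2-c2cc(OC)c(OC)c(OC)c2)cc1` gives 640 nM, so compound 2 stands level with compound 1 within the scatter. Compound 3 `COc1ccc(-c2cncnc2-c2cc(OC)c(OC)c(OC)c2)nc1` carries 5-methoxypyridin-2-yl in place of 4-ethoxyphenyl on an aromatic carbon. Among the measured compounds shown here, the only measured step, a 1.1-fold higher number from compound 1 to compound 2 (0.06 log units; within the scatter), put ethoxy in place of methylsulfanyl and stayed within the scatter. For the measured compounds named here, no measured step covers a ring with a nitrogen, so that evidence is only indirect. The estimated step is a 1.3-fold higher number from compound 2 to compound 3 (0.10 log units; within the scatter), expected to stay small but uncertain. For compound 3 the estimated value is 800 nM, with an expected range of 250 nM to 2500 nM.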

Compound 3, half-maximal inhibitory concentration: 1750 nM
Beside the measured number, compound 3's estimate is 2.2-fold (0.34 log units) below it; the range from low to high includes it.
By their numbers in this assay, from the lowest: compounds 1 and 2 (each within the scatter of the next); then compound 3.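

In this assay, this position on the ring with 2 nitrogen is not indifferent to the group it carries: 5-methoxypyridin-2-yl in place of 4-ethoxyphenyl gives a 2.7-fold higher number from compound 2 to compound 3 (0.44 log units; beyond the scatter) and in place of 4-(methylsulfanyl)phenyl gives a 3.1-fold higher number from compound 1 to compound 3 (0.49 log units; beyond the scatter) and both steps lie beyond the scatter. Among the compounds shown here, the earlier swap on the carbon-only ring did not leave the scatter, so this is the first measured change here, and it arrives with a ring nitrogen. No evidence on the cause of this loss is available. The compounds shown cannot separate the ring nitrogen from the change of ethoxy to methoxy, since compound 3 differs from compound 2 in both. From the compounds shown here alone, how an amine or a carboxylic acid on this ring would behave also remains open.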